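The source may hold more compounds than are shown below. What is called first, only, known or untested is meant among the compounds shown, and "the series" means these compounds.

Compound 1 `COc1cccc(/C=C2\CCC/C(=C\c3ccc(Cl)cc3)C2=O)c1OC` is tested in a functional assay on A549 cells (Homo sapiens) for cytotoxicity, read by MTT assay, with a stated time of 72 h (on this read-out lower numbers stand for stronger inhibition and higher numbers for weaker inhibition), and gives only a limit of the assay, > 20000 nM. Compound 2 `COc1cccc(/C=C2\CCC/C(=C\c3ccccc3Br)C2=O)c1OC` also gives only a limit, > 20000 nM. The change between them, (2-bromophenyl in place of 4-chlorophenyl on a double-bonded chain carbon bound to a double-bonded ring carbon), therefore produces a step that the two limits leave unreadable from compound 1 to compound 2. Among the compounds with values here, compound 3 `COc1ccc(/C=C2\CCC/C(=C\c3ccc(Cl)cc3)C2=O)cc1OC` gives the one real number of the set in this assay, 10100 nM; how its core differs from the core of compound 1 is not broken down here. Compound 4 `COc1ccc(/C=C2\CCC/C(=C\c3ccccc3Br)C2=O)cc1OC` carries the same change on the core of compound 3: 2-bromophenyl in place of 4-chlorophenyl on a double-bonded chain carbon bound to a double-bonded ring carbon. From compound 3 to compound 4 the step is expected to be a 1.5-fold higher number from compound 3 to compound 4 (0.17 log units; within the scatter), a cautious guess, since the matching step was unreadable and the limit of > 20000 nM in this assay, at which 2 of the 3 values shown sit, frames the series. In this assay compound 4 is expected to give 15000 nM, within 5000 nM to 40000 nM.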

Compound 4, half-maximal inhibitory concentration: > 20000 nM
Compound 4 was reported as a limit; the forecaster's own chance of this, stated with the estimate: 45%; middle value at least 1.3-fold (0.12 log units) from the limit.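

In this assay, 2-bromophenyl in place of 4-chlorophenyl on the second core gives an at least 1.9-fold higher number from compound 3 to compound 4 (0.29 log units; that floor lies within the scatter). That floor lies within the scatter, so the result does not establish a real loss of activity, and the matching step on the core of compound 1 cannot be read, which leaves no two step sizes to compare and no evidence on whether the change carries over from one core to the other. The series mostly reaches a single ceiling: the limit of > 20000 nM in this assay, at which 3 of the 4 values shown sit.

The halogen and its place on the phenyl group change together here, so the compounds shown leave open which of the two matters. On these data alone, it also remains open how 4-bromophenyl, 4-aminophenyl or 4-carboxyphenyl in the same place would behave on either core.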